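This account rests on a few compounds, and the source may have more. Where it says the series, first, only, none or still open, it means among the compounds named here.

Compound 1 `Cn1cncc1CN1CC(N(CC2CCN(C(=O)c3ccc(Cl)cc3)CC2)S(=O)(=O)c2ccccn2)Cc2cc(C#N)ccc21`, compound 2 `CCC(=O)N1CCC(CN(C2Cc3cc(C#N)ccc3N(Cc3cncn3C)C2)S(=O)(=O)c2ccccn2)CC1` and compound 3 `Cn1cncc1CN1CC(N(CC2CCN(C(=O)c3ccco3)CC2)S(=O)(=O)c2ccccn2)Cc2cc(C#N)ccc21` share one core and differ only in the group on a carbonyl carbon: 4-chlorophenyl in compound 1, ethyl in compound 2 and furan-2-yl in compound 3. In an ADME assay on Caco-2 cells (Homo sapiens) for permeability, in the apical to basolateral direction (on this read-out higher numbers stand for higher permeability and lower numbers for lower permeability), compound 1 gives 0.5 10^-6 cm/s. In this assay compound 2 gives 0.5 10^-6 cm/s. In this assay compound 3 gives 0.5 10^-6 cm/s. The three sit level: the step of no change at the digits printed from compound 1 to compound 2 (within the scatter), the step of no change at the digits printed from compound 1 to compound 3 (within the scatter) and the step of no change at the digits printed from compound 2 to compound 3 (within the scatter) all stay within the scatter, so compound 2 stands with compound 1 and compound 3 and is set apart from neither.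

Compound 4 `CCNC(=O)N1CCC(CN(C2Cc3cc(C#N)ccc3N(Cc3cncn3C)C2)S(=O)(=O)c2ccccn2)CC1` differs from compound 2 in one place: ethylamino in place of ethyl on a carbonyl carbon. Each measured step exchanged one group for another on this same carbonyl carbon and left this assay unchanged, which is the closest guide: no change at the digits printed from compound 1 to compound 2 (within the scatter) and no change at the digits printed from compound 2 to compound 3 (within the scatter). Among the compounds with values here, what is new here is that a hydrogen-bond donor enters, which none of the measured steps involved, so the guide is incomplete. Still, with every measured step flat, the step of a 1.3-fold lower number from compound 2 to compound 4 (0.10 log units; within the scatter) is expected to stay within the scatter, at most a slight drift downward. Compound 4 is therefore estimated at 0.4 10^-6 cm/s in this assay, with a range from 0.15 10^-6 cm/s to 1 10^-6 cm/s.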

Compound 4, apparent permeability: 0.6 10^-6 cm/s
For compound 4 the middle estimate is 1.5-fold (0.18 log units) below the measured one; the range from low to high includes it.
By their numbers in this assay, from the lowest: compounds 1, 2, 3 and 4 (each within the scatter of the next).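

Within the data shown here, compound 4 adds something the earlier steps on this carbonyl carbon did not contain: ethylamino places a nitrogen on that carbon and brings a hydrogen-bond donor that ethyl lacks. Even so, this assay shows a 1.2-fold higher number from compound 2 to compound 4 (0.08 log units; within the scatter), along with a 1.2-fold higher number from compound 3 to compound 4 (0.08 log units; within the scatter) and a 1.2-fold higher number from compound 1 to compound 4 (0.08 log units; within the scatter), so all four compounds stand level and this position has now tolerated the change from ethyl to ethylamino as well as the earlier exchanges among ethyl, 4-chlorophenyl and furan-2-yl without a step beyond the scatter. Nothing given alongside these values explains why the read-out stays level at this position.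

The compounds shown leave open whether a longer chain ending in an amine or a carboxylic acid, attached at this same carbonyl carbon, would also stay level with these four. They also leave open whether the same exchange from ethyl to ethylamino would stay within the scatter if the shared core were changed elsewhere.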